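A few compounds are considered here, and "the series" means these few. Any claim that something is new, unique, unknown or untested is made for them only; others in the source may bear on it.

Of the compounds shown here, two have so far been tested in an ADME assay on Vero cells (Chlorocebus sabaeus) for inhibition, read by MTT assay; a lower number here means that less compound is tolerated, a higher number that more compound is tolerated. Among the measured compounds shown here, compound 1, `O=C(O)COc1ccc(/C=C2/SC(=O)N(Cc3ccc(F)cc3)C2=O)cc1Br`, and compound 2, `O=C(C1=C(O)C(=O)N(c2nnc(SCc3ccccc3)s2)C1c1ccccc1)c1cc2ccccc2o1`, share no common core, so no step between measured compounds can be read here. In this assay compound 1 reaches only a limit of the assay, > 200000 nM. In this assay compound 2 likewise reaches only a limit of the assay, > 200000 nM. Compound 2 therefore stands where both values shown stand, at the limit of > 200000 nM in this assay, at which 2 of the 2 values shown sit, and no number beyond that limit is known for it.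

Compound 3, `O=C(C1=C(O)C(=O)N(c2nnc(SCc3ccccc3)s2)C1c1ccccc1F)c1cc2ccccc2o1`, is the next compound to be measured in this assay. It differs from compound 2 in one place: fluoro in place of hydrogen on an aromatic carbon, which cut one bond further out reads phenyl to 2-fluorophenyl. With both known values at the same limit, the step in this assay from compound 2 to compound 3 is expected to be none beyond the scatter, a number no higher from compound 2 to compound 3 (the limit leaves the size open). In this assay compound 3 is accordingly expected to give about 200000 nM, within a range from 100000 nM to 400000 nM, most likely again as a limit.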

Compound 3, half-maximal cytotoxic concentration: > 200000 nM
Compound 3 was reported as a limit (the forecaster's own chance of this, stated with the estimate: 85%); the middle value lies on the limit itself.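

Among the compounds shown here, compound 3 sits at the same limit of this assay as compound 2, so no step from compound 2 to compound 3 can be read: the limit of > 200000 nM in this assay, at which 3 of the 3 values shown sit. On these data alone, the actual half-maximal cytotoxic concentrations of compound 1, compound 2 and compound 3 stay open, as does whether fluoro in place of hydrogen on an aromatic carbon changes that read-out at all.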